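Two Sulfamoyl Carbamates and an Aryl Swap

The source may hold more compounds than are shown below. What is called first, only, known or untested is meant among the compounds shown, and "the series" means these compounds.

Measured so far:
Compound 1, `CC(C)c1cccc(C(C)C)c1OC(=O)NS(=O)(=O)Oc1c(F)cccc1F`, gives 38000 nM in an assay on liver for inhibition of sterol O-acyltransferase 1 (Rattus norvegicus), using microsomes; on this read-out higher numbers stand for weaker inhibition and lower numbers for stronger inhibition.
Compound 2, `Cc1cccc(C)c1OS(=O)(=O)NC(=O)Oc1c(C(C)C)cccc1C(C)C`, gives > 50000 nM in this assay; this is a limit of the assay and not a number.
Compound 3, `CC(C)c1cccc(C(C)C)c1OS(=O)(=O)NC(=O)Oc1c(F)cccc1F`, gives 65000 nM in this assay.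

Compound 1 and compound 3 are built from the same atoms joined differently; the difference between the two cores is not broken down here. Compound 1 and compound 3 stand within the usual scatter of each other in this assay, so no order between them can be read.

From compound 1 to compound 2 the change is 2,6-dimethylphenyl in place of 2,6-difluorophenyl on an oxygen. The step is an at least 1.3-fold higher number from compound 1 to compound 2 (0.11 log units; that floor lies within the scatter), and compound 2 sits at the limit of > 50000 nM in this assay, at which 1 of the 3 values shown sits.

Compound 4, `Cc1cccc(C)c1OC(=O)NS(=O)(=O)Oc1c(C(C)C)cccc1C(C)C`, is not yet measured. It differs from compound 3 by 2,6-dimethylphenyl in place of 2,6-difluorophenyl on an oxygen next to a carbonyl group. For the measured compounds named here, this is the same kind of change as the one from compound 1 to compound 2, but the place differs: there the oxygen's other neighbour is sulfonyl sulfur, here the oxygen is next to a carbonyl group and its other neighbour is carbonyl carbon.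

Compound 4 is expected to show a step of a 1.5-fold higher number from compound 3 to compound 4 (0.19 log units; within the scatter) in this assay, resting on the step of an at least 1.3-fold higher number from compound 1 to compound 2 (0.11 log units; that floor lies within the scatter) and on compound 3 already giving 65000 nM. Compound 4 is therefore estimated at 100000 nM, between 50000 nM and 250000 nM, and a reported limit rather than a number is expected to be likely, as for compound 2 at the limit of > 50000 nM in this assay, at which 1 of the 3 values shown sits.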

Compound 4, half-maximal inhibitory concentration: > 50000 nM
Compound 4 was reported as a limit; the forecaster's own chance of this, stated with the estimate: 75%; the middle value does not contradict the limit.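

In this assay compound 4 gives > 50000 nM; this is a limit of the assay and not a number. The step from compound 3 to compound 4 cannot be read, and compound 2 shares this limit: the limit of > 50000 nM in this assay, at which 2 of the 4 values shown sit.

The compounds shown leave open how 2,6-dimethylphenyl in place of 2,6-difluorophenyl acts on either oxygen, since neither compound 2 nor compound 4 has a readable number.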